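Opening the ring on the amide nitrogen

The source may hold more compounds than are shown below. What is called first, only, known or untested is meant among the compounds shown, and "the series" means these compounds.

Compound 1 is `O=C(CN(C(=O)c1cccnc1)C1CCCCC1)Nc1cc(F)cc(F)c1`; in an assay on HEK293 cells for inhibition of sodium- and chloride-dependent glycine transporter 1 (Homo sapiens), read by scintillation proximity assay (on this read-out lower numbers stand for stronger inhibition and higher numbers for weaker inhibition), compound 1 reaches only a limit, > 25100 nM, as noted in the limit of > 25100 nM in this assay, at which 1 of the 3 values shown sits. Compound 2 is `O=C(CN(CC1CC1)C(=O)c1ccc(-c2ccccn2)cc1)Nc1cc(F)cc(F)c1`; in this assay compound 2 gives 200 nM. Compound 3 is `O=C(CN(C(=O)c1ccc(-c2ccccn2)cc1)C1CCCOC1)Nc1cc(F)cc(F)c1`; in this assay compound 3 gives 79.4 nM.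

Compound 3 therefore holds the lowest of the two numbers shown, its nearest neighbour being compound 2 through the step of a 2.5-fold lower number from compound 2 to compound 3 (0.40 log units; beyond the scatter). Compound 4 is `COCC(C)N(CC(=O)Nc1cc(F)cc(F)c1)C(=O)c1ccc(-c2ccccn2)cc1`, and it differs from compound 3 by 1-(methoxymethyl)ethyl in place of oxan-3-yl on an amide-type nitrogen. Among the measured compounds shown here, only the step from compound 2 to compound 3 touches this nitrogen, and it was modest. The estimate for compound 4 is a step of a 1.5-fold higher number from compound 3 to compound 4 (0.18 log units; within the scatter), with compound 4 expected near 120 nM, between 45 nM and 320 nM.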

Compound 4, half-maximal inhibitory concentration: 1260 nM
Compound 4: middle estimate off by 11-fold (1.02 log units), on the low side; measured number outside the range, above it.
By their numbers in this assay, from the lowest: compound 3; then compound 2; then compound 4. At a limit, above all of these: compound 1.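

At this amide-type nitrogen, the change turns out to matter far more than the earlier step suggested: a 16-fold higher number from compound 3 to compound 4 (1.20 log units; beyond the scatter) is a large step, and a 6.3-fold higher number from compound 2 to compound 4 (0.80 log units; beyond the scatter) places the open chain behind cyclopropylmethyl as well. Oxan-3-yl and 1-(methoxymethyl)ethyl carry the same count of hydrogen-bond acceptors, so that count alone does not set the number here, while the ring is present in one and absent in the other. Nothing measured here accounts for the loss on opening the ring.

The compounds shown leave open whether the ring or the particular chain decides the outcome. They also leave open how an amine such as piperidin-3-yl would behave on this nitrogen.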